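The compounds below may be only part of what the source reports. "The series", "measured", "known", "first", "only" and "open" are said of these compounds alone.

Measured so far in a functional assay on MDA-MB-231 cells (Homo sapiens) for antiproliferative activity, read by CCK-8 assay, with a stated time of 48 h; a lower number here means a stronger inhibitor, a higher number a weaker inhibitor:
- compound 1 `C=C(C)C(=O)NCCOc1ccc(Oc2c(-c3ccc(F)cc3)sc3cc(O)ccc23)cc1`: > 50000 nM
- compound 2 `C/C=C/C(=O)N1CC(Oc2ccc(Oc3c(-c4ccc(F)cc4)sc4cc(O)ccc34)cc2)C1`: > 50000 nM

Compound 2 gives > 50000 nM, which is a limit and not a number. Compound 1 gives > 50000 nM, also a limit. So a step that the two limits leave unreadable from compound 1 to compound 2 has no readable size, and the only guide is the limit of > 50000 nM in this assay, at which 2 of the 2 values shown sit.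

Compound 3 `CNC(=O)/C=C/CNCCOc1ccc(Oc2c(-c3ccc(F)cc3)sc3cc(O)ccc23)cc1` carries 2-((3-(methylcarbamoyl)prop-2-en-1-yl)amino)ethyl in place of 1-((prop-1-en-1-yl)carbonyl)azetidin-3-yl on an oxygen on an aromatic ring. No measured step sizes this change, so only a small move towards stronger inhibition in this assay is expected, and the limit may well recur. The expected change is an at least 1.6-fold lower number from compound 2 to compound 3 (0.22 log units; that floor lies within the scatter). Compound 3 is estimated at 30000 nM, with an expected range of 10000 nM to 60000 nM.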

Compound 3, half-maximal inhibitory concentration: > 50000 nM
Compound 3 ended at the assay's limit; the forecaster's own chance of this, stated with the estimate: 50%; at least 1.6-fold (0.22 log units) between middle value and limit.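

Compound 3 also ends at a limit and not at a number, so no step from compound 1 or compound 2 to compound 3 can be read in this assay: the limit of > 50000 nM in this assay, at which 3 of the 3 values shown sit.

The compounds shown leave open whether any group on this oxygen on an aromatic ring would give a readable value in this assay.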